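Chloro added to the pyridine of compound 3

The compounds below may be only part of what the source reports. "The series", "measured", "known", "first", "only" and "open" are said of these compounds alone.

Compound 1 `O=C(c1ccc(Cl)cc1)N1CCC(NS(=O)(=O)c2cc(S(=O)(=O)c3ccccc3)ccc2C(F)(F)F)CC1`: 3100 nM
Compound 2 `CN(C)c1ccc(C(=O)N2CCC(NS(=O)(=O)c3cc(S(=O)(=O)c4ccccc4)ccc3C(F)(F)F)CC2)cc1`: 50000 nM
Compound 3 `O=C(c1cccnc1)N1CCC(NS(=O)(=O)c2cc(S(=O)(=O)c3ccccc3)ccc2C(F)(F)F)CC1`: 50000 nM
Compound 4 `O=C(c1ccc(Cl)nc1)N1CCC(NS(=O)(=O)c2cc(S(=O)(=O)c3ccccc3)ccc2C(F)(F)F)CC1`: not yet measured

In a physicochemical assay for solubility (on this read-out lower numbers stand for lower solubility and higher numbers for higher solubility), compound 3 shares the highest of the three numbers with compound 2, as the entry no change at the digits printed from compound 2 to compound 3 (within the scatter) shows. The next change is chloro in place of hydrogen on an aromatic carbon, pyridin-3-yl to 6-chloropyridin-3-yl (chloro in place of hydrogen on an aromatic carbon). Within the data shown here, no measured step makes this exact change. The closest evidence is two large steps away from the chloro of compound 1, namely a 16-fold higher number from compound 1 to compound 3 (1.21 log units; beyond the scatter) and a 16-fold higher number from compound 1 to compound 2 (1.21 log units; beyond the scatter). Putting chloro back is therefore expected to lower the number, by less than those steps. The expected step is a 4.2-fold lower number from compound 3 to compound 4 (0.62 log units; beyond the scatter). For compound 4 the estimated value is 12000 nM, with an expected range of 3000 nM to 50000 nM.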

Compound 4, solubility: 25000 nM
The estimate for compound 4 lay 2.1-fold (0.32 log units) below the measured number; measured number inside the range.
By their numbers in this assay, from the lowest: compound 1; then compounds 4, 2 and 3 (each within the scatter of the next).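

In this assay, chloro on the aromatic carbon next to the ring nitrogen, para to a large group, is tolerated on the pyridine (a 2.0-fold lower number from compound 3 to compound 4 (0.30 log units; within the scatter)), and the 6-chloropyridin-3-yl group also stays close to the 4-(dimethylamino)phenyl group (a 2.0-fold lower number from compound 2 to compound 4 (0.30 log units; within the scatter)). Chloro alone therefore does not return the series to the level of compound 1, since the 6-chloropyridin-3-yl group still reads well apart from the 4-chlorophenyl group (an 8.1-fold higher number from compound 1 to compound 4 (0.91 log units; beyond the scatter)). No measurement here speaks to the origin of these steps.

Open, on these data alone, is whether a methoxy group or a primary amine on this same carbon would read differently from chloro. Also open, as far as these compounds go, is how chloro reads on other carbons of the pyridine.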